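Amine substituent variation and paw edema inhibition

A few compounds are considered here, and "the series" means these few. Any claim that something is new, unique, unknown or untested is made for them only; others in the source may bear on it.

Measured compounds:
compound 1 `N#CC1=C(NCN2CCCC2)N(c2ccccc2)C(=O)N2CCCCC(N3CCCC3)C12`: 26.6%
compound 2 `N#CC1=C(NCC(=O)N2CCCC2)N(c2ccccc2)C(=O)N2CCCCC(N3CCCC3)C12`: 49.8%
compound 3 `COc1ccc(/C=N/C2=C(C#N)C3C(N4CCCC4)CCCCN3C(=O)N2c2ccccc2)cc1`: 71.6%

In a functional assay on the whole organism (strain albino) for inhibition, with Rattus norvegicus as the target, read by paw edema, with stated times of 1 h and 2 h, at a dose of 20 mmol/kg by the intraperitoneal route (a higher number here means more inhibition at the dose given (going by the name of the read-out), a lower number less inhibition), compound 2 stands second highest of the three values. Both steps that touch it lie beyond the scatter: a number 23.2 percentage points higher from compound 1 to compound 2 (beyond the scatter) and a number 21.8 percentage points higher from compound 2 to compound 3 (beyond the scatter). Compound 4 `COC(=O)C(=O)NC1=C(C#N)C2C(N3CCCC3)CCCCN2C(=O)N1c1ccccc1` is not yet measured in this assay. It differs from compound 2 in one place: (methoxycarbonyl)carbonyl in place of ((pyrrolidin-1-yl)carbonyl)methyl on an amine nitrogen.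

Going by the values given here, two measured steps bear on this change. Among the compounds with values here, the step of a number 23.2 percentage points higher from compound 1 to compound 2 (beyond the scatter) is the only one that alters the group on the amine nitrogen while keeping a chain there, and it shows that bringing a carbonyl into that group gave a modest rise. The step of a number 21.8 percentage points higher from compound 2 to compound 3 (beyond the scatter) shows that exchanging the whole chain for a different group also gave a modest rise, so every change away from the group of compound 1 has so far raised the number. Within the data shown here, no measured step removes the five-membered ring or places a carbonyl directly on the amine nitrogen, so the direction for compound 4 rests on analogy only. A modest rise, or no step beyond the scatter, is expected for compound 4: a number 6.2 percentage points higher from compound 2 to compound 4 (within the scatter). Compound 4 is therefore estimated at 56%, in the range 36% to 76%.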

Compound 4, a percentage reported as inhibition, in the whole organism at one dose (the size of the read-out at that dose, not a potency): 85.6%
For compound 4 the middle estimate is 29.6 percentage points below the measured one; measured number outside the range, above it.
By their numbers in this assay, from the lowest: compound 1; then compound 2; then compound 3; then compound 4.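

In this assay, the exchange of ((pyrrolidin-1-yl)carbonyl)methyl for (methoxycarbonyl)carbonyl on the amine nitrogen gives a number 35.8 percentage points higher from compound 2 to compound 4 (beyond the scatter) and the exchange of (pyrrolidin-1-yl)methyl for the same group gives a number 59 percentage points higher from compound 1 to compound 4 (beyond the scatter) so a group with no ring at this nitrogen can reach the highest number of the four compounds. Against the group of compound 3, which holds a six-membered aromatic ring of carbon only, the change gives a number 14 percentage points higher from compound 3 to compound 4 (beyond the scatter) and neither that ring nor the five-membered ring is therefore needed at this position for a high number at this dose. No measurement bears on why the number rises with this group.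

Open, on these data alone, is which part of (methoxycarbonyl)carbonyl goes with the rise: the carboxylic acid, the primary amide, the ethyl ester or a plain acetyl group on the same nitrogen would separate the ester from the second carbonyl. Also open, as far as these compounds go, is how the inhibition follows the dose, since each compound stands here at a single dose, which gives the size of the read-out and not a potency.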